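The compounds below may be only part of what the source reports. "The series", "measured", "known", "first", "only" and "open" are said of these compounds alone.

Measured compounds:
- Compound 1 `CC1(OC(=O)N2CCC3(CC2)CC(CCCOc2ccc(S(C)(=O)=O)c(F)c2)C3)CC1`: in a functional assay on cells for agonist activity at Glucose-dependent insulinotropic receptor (Homo sapiens), read by HTRF and cAMP accumulation, with a stated time of 30 min (a lower number here means that less compound is needed, a higher number that more compound is needed for the effect), compound 1 gives 13 nM
- Compound 2 `CS(=O)(=O)c1ccc(OCCCC2CC3(CCN(C(=O)OC4CCCC4)CC3)C2)cc1F`: in this assay compound 2 gives 23 nM
- Compound 3 `CC(C)(C)COC(=O)N1CCC2(CC1)CC(CCCOc1ccc(S(C)(=O)=O)c(F)c1)C2`: in this assay compound 3 gives 31 nM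

Compound 3 has the highest of the three numbers. Its nearest neighbour is compound 2, and a 1.3-fold higher number from compound 2 to compound 3 (0.13 log units; within the scatter) lies within the scatter, so the two cannot be ranked. The distance to compound 1 is larger: a 2.4-fold higher number from compound 1 to compound 3 (0.38 log units; beyond the scatter) is a modest step, beyond the scatter. Compound 4 `CCc1cnc(N2CCC3(CC2)CC(CCCOc2ccc(S(C)(=O)=O)c(F)c2)C3)nc1` differs from compound 3 in one place: 5-ethylpyrimidin-2-yl in place of neopentyloxycarbonyl on an amine nitrogen in a ring.

All three measured steps vary only the group on the oxygen next to the carbonyl group: a 1.8-fold higher number from compound 1 to compound 2 (0.25 log units; within the scatter) and a 2.4-fold higher number from compound 1 to compound 3 (0.38 log units; beyond the scatter) and a 1.3-fold higher number from compound 2 to compound 3 (0.13 log units; within the scatter). They show that swapping one such group for another moves the number by little, at most a modest amount. Within the data shown here, none of them removes the oxygen and carbonyl altogether, which is what the change to compound 4 does, so no measured step directly covers it. Among the measured compounds shown here, the expectation for compound 4 is therefore only that the number stays in the same general region as the three measured values, with no direction predicted and with wide uncertainty. Compound 4 is estimated at 30 nM, with a range from 8 nM to 120 nM, which corresponds to an expected step of a 1.0-fold lower number from compound 3 to compound 4 (0.01 log units; within the scatter).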

Compound 4, half-maximal effective concentration: 123 nM
Compound 4: middle estimate off by 4.1-fold (0.61 log units), on the low side, and the stated range ends below it.
By their numbers in this assay, from the lowest: compounds 1, 2 and 3 (each within the scatter of the next, the first and the last beyond it); then compound 4.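

In this assay, taking away the whole neopentyloxycarbonyl group and putting 5-ethylpyrimidin-2-yl on the amine nitrogen in the ring gives a 4.0-fold higher number from compound 3 to compound 4 (0.60 log units; beyond the scatter), and the same kind of exchange gives a 5.3-fold higher number from compound 2 to compound 4 (0.73 log units; beyond the scatter) and a 9.5-fold higher number from compound 1 to compound 4 (0.98 log units; beyond the scatter). Each of these steps is larger than any seen when only the group on the oxygen changed, so this position accepts swaps of that group far better than the loss of the oxygen and carbonyl together with the arrival of an aromatic ring, even though the groups that leave and enter match in their counts of heavy atoms and hydrogen-bond acceptors. Nothing available explains why the number rises with this change.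

The compounds shown leave open whether the rise comes from the pyrimidine ring itself or from its ethyl group, which a plain pyrimidin-2-yl or a 5-methylpyrimidin-2-yl would help to separate. They also leave open whether a different ring, such as phenyl, or a group that keeps the carbonyl but drops the oxygen, such as an acetyl or a urea, would fall closer to the oxygen-linked compounds.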